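The compounds below may be only part of what the source reports. "The series", "measured", "known", "first", "only" and "open" are said of these compounds alone.

On these data alone, compound 1 `O=C(CSc1nnnn1-c1cccc2ccccc12)N/N=C/c1ccccc1F` gives in an ADME assay on MT4 cells (Homo sapiens) for cytotoxicity, read by MTT assay (on this read-out lower numbers stand for higher toxicity in this test and higher numbers for lower toxicity in this test), only a limit, >= 118000 nM, so where compound 1 truly stands on this read-out stays open (the limit of >= 118000 nM in this assay, at which 1 of the 2 values shown sits). Compound 2 `COc1ccc(O)c(/C=N/NC(=O)CSc2nnnn2-c2cccc3ccccc23)c1` gives 4510 nM in this assay, and the step of an at least 26-fold lower number from compound 1 to compound 2 (1.41 log units; beyond the scatter) is large. Compound 3 `O=C(CSc1nnnn1-c1cccc2ccccc12)N/N=C/c1ccccc1` differs from compound 1 as follows: hydrogen in place of fluoro on an aromatic carbon. For the measured compounds named here, the one measured step concerns a different replacement at that carbon, so no measured step bears on removing the fluoro; the expected step of a number no higher from compound 1 to compound 3 (the limit leaves the size open) is none beyond the scatter. Compound 3 is therefore estimated at 118000 nM, range 40000 nM to 300000 nM, most likely reported again only as a limit.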

Compound 3, half-maximal cytotoxic concentration: 216000 nM
The estimate for compound 3 lay 1.8-fold (0.26 log units) below the measured number, within the range that was stated.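

In this assay, compound 3 gives this position a reference that is an exact number rather than a limit, so the size of the 2-hydroxy-5-methoxyphenyl change can now be read: phenyl in its place gives a 48-fold higher number from compound 2 to compound 3 (1.68 log units; beyond the scatter). The step from compound 1 to compound 3 cannot be read, because the value of compound 1 is a limit: the limit of >= 118000 nM in this assay, at which 1 of the 3 values shown sits.

The compounds shown leave open whether the hydroxy or the methoxy accounts for the step on its own. They also leave open how an amine or a carboxylic acid on the phenyl would read here.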